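A few compounds are considered here, and "the series" means these few. Any claim that something is new, unique, unknown or untested is made for them only; others in the source may bear on it.

The set holds three measured compounds and one still to be measured, all read in an ADME assay on HepG2 2.2.15 cells (Homo sapiens) for cytotoxicity, read by MTT assay, with a stated time of 8 days; a lower number here means that less compound is tolerated, a higher number that more compound is tolerated. Compound 1 `N#Cc1ccc(Cn2nc(-c3cc(Cl)c(NC[C@H](O)CO)nc3F)c3ccccc3c2=O)cc1` gives in this assay only a limit of the assay, > 100000 nM. Compound 2 `CC(=O)Nc1ccc(-c2nn(Cc3ccc(C#N)cc3)c(=O)c3ccccc23)c(F)n1` likewise gives in this assay only a limit, > 100000 nM. Compound 3 `O=c1c(C2CC2)cc(-c2ccc(F)nc2F)nn1Cc1ccc(Cl)cc1` gives in this assay a number, 39800 nM. Compound 2 thus stands at the limit of > 100000 nM in this assay, at which 2 of the 3 values shown sit, and the numbers give it no finer place than that among the three. Going by the values given here, no step between two measured compounds that differ in one place is available, so no measured step can be quoted.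

Compound 4 `CN(C)c1ccc(-c2nn(Cc3ccc(C#N)cc3)c(=O)c3ccccc23)c(F)n1` differs from compound 2 in one place: dimethylamino in place of acetamido on an aromatic carbon. Among the compounds with values here, with no measured pair of this kind, the size of the step has to be expected rather than read off. Compound 2 gives in this assay only a limit, > 100000 nM. From that starting point, the expected step is a number no higher from compound 2 to compound 4 (the limit leaves the size open), none beyond the scatter, with the outcome most likely again a limit rather than a number. Compound 4 is therefore expected to give in this assay 100000 nM, with a range from 30000 nM to 300000 nM.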

Compound 4, half-maximal cytotoxic concentration: 79200 nM
Compound 4: the middle estimate sits 1.3-fold (0.10 log units) above what was measured; the range from low to high includes it.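

In this assay, going by these compounds alone, the exchange of acetamido for dimethylamino on this aromatic carbon, next to the ring nitrogen and para to a large group, gives an at least 1.2-fold lower number from compound 2 to compound 4 (0.10 log units; that floor lies within the scatter), and this is the only measured step at this position. Compound 4 gives 79200 nM, so this change on the shared core yields a number that can be read, and the change takes away the hydrogen-bond donor and the double bond of acetamido without a step shown to lie beyond the scatter. The true size of the step stays unread because compound 2 gives only a limit of the assay: the limit of > 100000 nM in this assay, at which 2 of the 4 values shown sit.

The compounds shown leave open whether a plain amine, a diethylamino group or a carboxylic acid on this carbon would give a number near that of compound 4 or only a limit. They also do not separate the part played by the hydrogen-bond donor from that of the carbonyl, and a methylamino group or a longer acyl chain on the same carbon would bear directly on that question.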